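Swapping a bromine for a hydroxyl on the side ring

The compounds below may be only part of what the source reports. "The series", "measured", "known", "first", "only" and "open" are said of these compounds alone.

Of the compounds shown here, three sharing one core have been measured in an ADME assay on NHDF cells (Homo sapiens) for cytotoxicity; a lower number here means a stronger inhibitor, a higher number a weaker inhibitor. Compound 1 `COc1cccc(/C=C2\CCC/C(=C\c3cc(OC)c(OC)c(OC)c3)C2=O)c1OC` gives 18800 nM. Compound 2 `COc1cc(/C=C2\CCC/C(=C\c3ccc(O)c(O)c3)C2=O)cc(OC)c1OC` gives 9000 nM. Compound 3 `COc1cc(/C=C2\CCC/C(=C\c3ccccc3Br)C2=O)cc(OC)c1OC` gives 12400 nM. Compound 3 therefore sits within the scatter of both neighbours: the differences a 1.5-fold lower number from compound 1 to compound 3 (0.18 log units; within the scatter) and a 1.4-fold higher number from compound 2 to compound 3 (0.14 log units; within the scatter) are both too small to count as real change. For the measured compounds named here, the only step beyond the scatter is a 2.1-fold lower number from compound 1 to compound 2 (0.32 log units; beyond the scatter), where hydroxyl groups enter in place of methoxy groups.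

Compound 4 `COc1cc(/C=C2\CCC/C(=C\c3cccc(O)c3)C2=O)cc(OC)c1OC` has not yet been measured. Its change from compound 3 is 3-hydroxyphenyl in place of 2-bromophenyl on a double-bonded chain carbon bound to a double-bonded ring carbon. The step most like it in reverse is a 1.4-fold higher number from compound 2 to compound 3 (0.14 log units; within the scatter), where a hydroxyl-bearing ring gave way to the bromophenyl and nothing beyond the scatter resulted. A hydroxyl entering is thus expected to give at most a small shift, a 1.2-fold lower number from compound 3 to compound 4 (0.09 log units; within the scatter), towards a lower number. Compound 4 is estimated at 10000 nM in this assay, expected to fall between 5000 nM and 20000 nM.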

Compound 4, half-maximal inhibitory concentration: 25300 nM
The estimate for compound 4 lay 2.5-fold (0.40 log units) below the measured number; measured number above the stated range.
By their numbers in this assay, from the lowest: compounds 2, 3, 1 and 4 (each within the scatter of the next, the first and the last beyond it).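

In this assay, a hydroxyl entering at this place does not by itself bring the number down: with 3-hydroxyphenyl in place of 2-bromophenyl, the result is a 2.0-fold higher number from compound 3 to compound 4 (0.31 log units; beyond the scatter). The count of hydroxyls on the ring also matters, since hydrogen in place of one hydroxy on an aromatic carbon gives a 2.8-fold higher number from compound 2 to compound 4 (0.45 log units; beyond the scatter), so the 3,4-dihydroxyphenyl and 3-hydroxyphenyl rings cannot be treated as alike. The change from the 2,3-dimethoxyphenyl ring of compound 1 is smaller, a 1.3-fold higher number from compound 1 to compound 4 (0.13 log units; within the scatter), and counts as no real change. On these data alone, whether an amine or a carboxylic acid on this ring would behave like the hydroxyl or like the bromine remains open. Nothing measured here says what lies behind these shifts.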